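This account rests on a few compounds, and the source may have more. Where it says the series, first, only, none or still open, it means among the compounds named here.

Of the compounds shown here, two sharing one core have been measured in a functional assay on the whole organism for inhibition, with Rattus norvegicus as the target, read by paw edema, in the formalin test, with a stated time of 8 h, at a dose of 100 mg/kg by the intraperitoneal route; a higher number here means more inhibition at the dose given (going by the name of the read-out), a lower number less inhibition. Compound 1 `O=c1cc(CNc2nc(-c3cc4cc(Br)cc(Br)c4oc3=O)cs2)c2cc(Cl)ccc2[nH]1` gives 21.9% in this assay, and compound 2 `Cc1cccc2c(CNc3nc(-c4cc5cc(Br)cc(Br)c5oc4=O)cs3)cc(=O)[nH]c12` gives 33.7% in this assay. Compound 1 therefore stands lowest of the two numbers, and its gap to compound 2 lies beyond the usual scatter of such measurements. Compound 3 `O=c1cc(CNc2nc(-c3cc4cc(Br)ccc4oc3=O)cs2)c2cc(Cl)ccc2[nH]1` has not yet been measured. It differs from compound 1 in a single place: hydrogen in place of bromo on an aromatic carbon. Within the data shown here, no pair of measured compounds differs in just this way, so nothing measured so far tells how this change moves the reading. The expected step of a number 1.9 percentage points lower from compound 1 to compound 3 (within the scatter) is small, not beyond the scatter, in either direction. Compound 3 is thus estimated to give about 20% in this assay, with a likely range from 8% to 33%.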

Compound 3, a percentage reported as inhibition, in the whole organism at one dose (the size of the read-out at that dose, not a potency): 28.6%
Compound 3: middle estimate off by 8.6 percentage points, on the low side; measured number inside the range.
By their numbers in this assay, from the lowest: compounds 1, 3 and 2 (each within the scatter of the next, the first and the last beyond it).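

Among these compounds, this is the first direct look at this position: in this assay, replacing the bromo group on the aromatic carbon ortho to a fused ring with hydrogen gives a number 6.7 percentage points higher from compound 1 to compound 3 (within the scatter). At this dose, then, the reading does not measurably depend on this bromo group, and inhibition is still seen without it while the other bromo group stays in place. No available measurement bears on why this is so.

This single pair cannot show whether the same change would read the same way on a different core, or what the remaining bromo group contributes. It also leaves open whether another group at this position, such as methoxy or an amine, would move the reading beyond the usual scatter.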